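Trifluoromethoxy for Trifluoromethyl: Expected Clearance of Compound 4

This account rests on a few compounds, and the source may have more. Where it says the series, first, only, none or still open, it means among the compounds named here.

Of the compounds shown here, three have been measured in an ADME assay on liver for metabolic stability, with Liver microsome (Rattus norvegicus) as the target, read by LC-MS, using microsomes, with a stated time of 5 h; on this read-out lower numbers stand for slow clearance and higher numbers for fast clearance. Compound 1 `C[C@]1(O)C[C@](c2cccc(OC(F)(F)F)c2)([C@H](O)c2ccccn2)C1` gives 50 mL/min/kg, compound 2 `C[C@]1(O)C[C@](c2cccc(C(F)(F)F)c2)([C@H](O)c2ccccn2)C1` gives 66.7 mL/min/kg, and compound 3 `C[C@]1(O)C[C@@](c2ccc(C(F)(F)F)cc2)([C@H](O)c2ccccn2)C1` gives 150 mL/min/kg in this assay, the highest of the three numbers. Compound 2 and compound 1 differ in one place, (trifluoromethoxy in place of trifluoromethyl on an aromatic carbon), and the step was a 1.3-fold lower number from compound 2 to compound 1 (0.13 log units; within the scatter). Compound 3 and compound 2 are built from the same atoms joined differently; the difference between the two cores is not broken down here.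

Compound 4 `C[C@]1(O)C[C@@](c2ccc(OC(F)(F)F)cc2)([C@H](O)c2ccccn2)C1` has not yet been measured in this assay. It differs from compound 3 by trifluoromethoxy in place of trifluoromethyl on an aromatic carbon. This is the same kind of change as that from compound 2 to compound 1, but not the same: in compound 1 the trifluoromethoxy sits meta to a large group, whereas in compound 4 it sits para to a large group.

Compound 4 is expected to give about 115 mL/min/kg in this assay, most likely between 70 mL/min/kg and 190 mL/min/kg, because the comparable earlier step a 1.3-fold lower number from compound 2 to compound 1 (0.13 log units; within the scatter) lay within the scatter. Compound 4 is thus expected to show a step of a 1.3-fold lower number from compound 3 to compound 4 (0.12 log units; within the scatter), a small move from the high clearance of compound 3.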

Compound 4, clearance: 133 mL/min/kg
For compound 4 the middle estimate is 1.2-fold (0.06 log units) below the measured one, and the stated range covers the measured number.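

In this assay, trifluoromethoxy in place of trifluoromethyl gave a 1.1-fold lower number from compound 3 to compound 4 (0.05 log units; within the scatter), so on this second core the swap again left the clearance number inside the scatter. The change carried over from one core to the other with much the same small size: the same change on two cores in this assay, a 1.3-fold lower number (0.13 log units; within the scatter) from compound 2 to compound 1 and a 1.1-fold lower number (0.05 log units; within the scatter) from compound 3 to compound 4, 1.2-fold (0.07 log units) apart, within the scatter of two such steps. For the compounds shown here, this shows only that the swap made no readable difference in the two cases at hand, one on each core; with both steps inside the scatter, it does not show that trifluoromethoxy truly lowers clearance, and two cores cannot promise the same result on a third.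

The compounds shown leave open whether another group on the same aromatic carbon, such as a nitrile, a methoxy group or a carboxylic acid, would move the clearance number by more than the scatter. Also open, from the compounds shown here alone, is whether the swap would stay this small on a core that carries an amine or a longer chain.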